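Aryl swap on the ring nitrogen of the shared core

The source may hold more compounds than are shown below. What is called first, only, known or untested is meant among the compounds shown, and "the series" means these compounds.

Compound 3 `Cc1ccc2nc(NC(=O)CSc3nc4c(c(=O)n3-c3ccc(F)cc3)SCC4)sc2c1` gives 40 nM in an assay on L cells for inhibition of Protein-serine O-palmitoleoyltransferase porcupine (Mus musculus), read by reporter gene assay, with a stated time of 24 h; a lower number here means that less compound is needed, a higher number that more compound is needed for the effect; compound 1 `COc1ccccc1-n1c(SCC(=O)Nc2nc3ccc(C(F)(F)F)cc3s2)nc2c(c1=O)SCC2` gives 30 nM, and compound 2 `O=C(CSc1nc2c(c(=O)n1-c1ccc(F)cc1)SCC2)Nc1nc2ccc(Cl)cc2s1` gives 175 nM. Compound 4 `COc1ccccc1-n1c(SCC(=O)Nc2nc3ccc(C)cc3s2)nc2c(c1=O)SCC2` differs from compound 3 by 2-methoxyphenyl in place of 4-fluorophenyl on an aromatic nitrogen. Among the measured compounds shown here, the only step among the measured compounds, a 4.4-fold lower number from compound 2 to compound 3 (0.64 log units; beyond the scatter), touches a different place and does not bear on this change directly. Like compound 4, compound 1 carries a 2-methoxyphenyl, and compound 1 gives 30 nM in this assay, close to compound 3. A step of no more than the scatter is therefore expected, as a 1.3-fold lower number from compound 3 to compound 4 (0.12 log units; within the scatter). Compound 4 is estimated at 30 nM, between 10 nM and 90 nM.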

Compound 4, half-maximal effective concentration: 25 nM
Compound 4: the middle estimate sits 1.2-fold (0.08 log units) above what was measured; the range from low to high includes it.
By their numbers in this assay, from the lowest: compounds 4, 1 and 3 (each within the scatter of the next); then compound 2.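

On the aromatic nitrogen of the shared core, 2-methoxyphenyl in place of 4-fluorophenyl now has a direct reading in this assay: a 1.6-fold lower number from compound 3 to compound 4 (0.20 log units; within the scatter) leaves the two aryl groups indistinguishable. With 2-methoxyphenyl on that nitrogen, a 1.2-fold lower number from compound 1 to compound 4 (0.08 log units; within the scatter) shows no separation between methyl and trifluoromethyl on the aromatic carbon, whereas with 4-fluorophenyl there, a 4.4-fold lower number from compound 2 to compound 3 (0.64 log units; beyond the scatter) marks methyl against chloro as a step beyond the scatter. No measurement at hand accounts for either reading.

Still open, from the compounds shown here alone, is whether a cyclohexyl group, or a phenyl carrying an amine, on that nitrogen would stay within the scatter of compound 4.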